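Side-chain amine swap: diethylamino to diisopropylamino

The compounds below may be only part of what the source reports. "The series", "measured", "known", "first", "only" and "open" are said of these compounds alone.

In a functional assay on SK-BR-3 cells (Homo sapiens) for antiproliferative activity (on this read-out higher numbers stand for weaker inhibition and lower numbers for stronger inhibition), compound 1 `CC(C)=CCc1cc(C(=O)Nc2cc3ccc(OCC4CCCNC4)c(C)c3oc2=O)ccc1O` gives 600 nM and compound 2 `CCN(CC)CCCOc1ccc2cc(NC(=O)c3ccc(O)c(CC=C(C)C)c3)c(=O)oc2c1C` gives 4900 nM as the higher of the two numbers, which places compound 2 on the weaker side of this pair. Among the compounds with values here, the only measured step (an 8.2-fold higher number from compound 1 to compound 2 (0.91 log units; beyond the scatter)) puts 2-(diethylamino)ethyl in place of piperidin-3-yl and lies beyond the scatter. Compound 3 `CC(C)=CCc1cc(C(=O)Nc2cc3ccc(OCCCN(C(C)C)C(C)C)c(C)c3oc2=O)ccc1O` departs from compound 2 in one place: diisopropylamino in place of diethylamino on a saturated chain carbon, three bonds along the chain from an oxygen on an aromatic ring (3-(diethylamino)propyl to 3-(diisopropylamino)propyl). Within the data shown here, no measured step exchanges diethylamino for diisopropylamino, so that modest step is only a loose guide to size. Compound 2 at 4900 nM therefore serves as the anchor. The estimated step in this assay (a 1.2-fold lower number from compound 2 to compound 3 (0.09 log units; within the scatter)) is expected to stay within the scatter, with no firm direction. Compound 3 is estimated at 4000 nM with an expected range from 1500 nM to 11000 nM on this evidence.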

Compound 3, half-maximal inhibitory concentration: 1600 nM
Estimate against measurement, compound 3: 2.5-fold (0.40 log units) above; low and high end bracket the measured number.
By their numbers in this assay, from the lowest: compound 1; then compound 3; then compound 2.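

In this assay, the change from 3-(diethylamino)propyl to 3-(diisopropylamino)propyl leaves the chain untouched and still gives a shift beyond the usual scatter (a 3.1-fold lower number from compound 2 to compound 3 (0.49 log units; beyond the scatter)), so this position responds to the alkyl groups on the chain amine alone. The new compound recovers only part of the gap to the piperidin-3-yl compound (a 2.7-fold higher number from compound 1 to compound 3 (0.43 log units; beyond the scatter)), and compound 1 keeps the lowest number of the three.

The compounds shown leave open how a pyrrolidine or a morpholine on the same propyl chain would read, and whether dimethylamino would extend the order seen with diethylamino and diisopropylamino. They also do not separate the effect of the ring in compound 1 from that of its shorter link to the oxygen.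

No measurement beyond these antiproliferative numbers bears on this shift.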